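Swapping Methyl for Chloro on a Shared Core

The compounds below may be only part of what the source reports. "The series", "measured", "known", "first", "only" and "open" are said of these compounds alone.

Compound 1 `O=C(Nc1nnn[nH]1)c1cc(=O)c2ccccc2o1` gives 100% in a functional assay on the whole organism for inhibition, with Rattus norvegicus as the target, with a stated time of 30 min, at a dose of 1 mg/kg by the intravenous route; on this read-out lower numbers stand for less inhibition and higher numbers for more inhibition at the one dose given (going by the name of the read-out).
Compound 2 `N#Cc1ccc2oc(C(=O)Nc3nnn[nH]3)cc(=O)c2c1` gives 100% in this assay.
Compound 3 `Cc1ccc2oc(C(=O)Nc3nnn[nH]3)cc(=O)c2c1` gives 75% in this assay.

Three compounds share one core and differ only in a single group on the carbon-only six-membered ring. Compound 1 carries hydrogen there, compound 2 a cyano group, and compound 3 a methyl group. Compound 3 stands lowest of the three: the step of a number 25 percentage points lower from compound 1 to compound 3 (beyond the scatter) and the step of a number 25 percentage points lower from compound 2 to compound 3 (beyond the scatter) both go beyond the usual scatter, while the step of no change at the digits printed from compound 1 to compound 2 (within the scatter) stays within it.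

Compound 4 `O=C(Nc1nnn[nH]1)c1cc(=O)c2cc(Cl)ccc2o1` has not yet been measured. It differs from compound 3 in one place: chloro in place of methyl on an aromatic carbon. Going by the values given here, no measured step shows what chloro does at this position. Hydrogen and cyano both sit at the top, and only methyl pulls the number down, so a group other than methyl is expected to return at least part of the way. The estimated step is a number 15 percentage points higher from compound 3 to compound 4 (beyond the scatter). Compound 4 is therefore expected to give about 90% in this assay, with a range from 65% to 100%.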

Compound 4, a percentage reported as inhibition, in the whole organism at one dose (the size of the read-out at that dose, not a potency): 65%
Beside the measured number, compound 4's estimate is 25 percentage points above it; measured number inside the range.
By their numbers in this assay, from the lowest: compounds 4 and 3 (each within the scatter of the next); then compounds 1 and 2 (each within the scatter of the next).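

Chloro in place of methyl gives a number 10 percentage points lower from compound 3 to compound 4 (within the scatter) in this assay, so the lower number of compound 3 is not unique to methyl: at this position, the two groups cannot be told apart in this read-out. The gap from the top of the series is now seen with a second group, as chloro in place of cyano gives a number 35 percentage points lower from compound 2 to compound 4 (beyond the scatter) and chloro in place of hydrogen gives a number 35 percentage points lower from compound 1 to compound 4 (beyond the scatter), which places compound 3 and compound 4 together and apart from compound 1 and compound 2. The data offer no measured property that could explain this split, so its reason remains unknown.

As far as these compounds go, with so few compounds, it remains open whether an amine, a methoxy group or a carboxylic acid at this position would stay with hydrogen and cyano or fall with methyl and chloro. Because each number comes from a single dose, these results also leave open how the compounds compare in potency, including whether compound 1 and compound 2 would still match at a lower dose.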